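Series notes: aryl swap at the ortho position of the core

The compounds below may be only part of what the source reports. "The series", "measured", "known", "first", "only" and "open" are said of these compounds alone.

Two compounds carry the shared core of compound 1 `CC(C(=O)NCc1ccc(C(F)(F)F)cc1N1CCC(C(F)(F)F)CC1)c1ccc(NS(C)(=O)=O)c(F)c1` and differ only in the group on the aromatic carbon meta to the trifluoromethyl group. In an assay on CHO cells for antagonist activity at transient receptor potential cation channel subfamily V member 1 (Homo sapiens), read by FLIPR (on this read-out lower numbers stand for stronger inhibition and higher numbers for weaker inhibition), compound 1 gives 0.4 nM. Among the measured compounds shown here, compound 2 `CC(C(=O)NCc1ccc(C(F)(F)F)cc1SCc1ccco1)c1ccc(NS(C)(=O)=O)c(F)c1` gives 3.2 nM in this assay, the highest of the two numbers known so far; the only step measured, an 8.0-fold higher number from compound 1 to compound 2 (0.90 log units; beyond the scatter), separates it from compound 1.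

Compound 3 `COc1cc(OC)cc(-c2cc(C(F)(F)F)ccc2CNC(=O)C(C)c2ccc(NS(C)(=O)=O)c(F)c2)c1` is the next member, not yet measured in this assay. Its change from compound 2 is 3,5-dimethoxyphenyl in place of ((furan-2-yl)methyl)sulfanyl on an aromatic carbon. For the measured compounds named here, no measured step involves a 3,5-dimethoxyphenyl group or this exchange, so the single step of an 8.0-fold higher number from compound 1 to compound 2 (0.90 log units; beyond the scatter) bears on it only indirectly: it shows that a large group at this carbon of the core is compatible with a low number, and that exchanging it shifts the number modestly.

Compound 3 is therefore expected to land near compound 2 or somewhat lower, with the estimated step of a 1.6-fold lower number from compound 2 to compound 3 (0.20 log units; within the scatter) carrying broad uncertainty. The expected value for compound 3 is 2 nM, within a range of 0.5 nM to 10 nM.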

Compound 3, inhibition constant: 5.8 nM
Compound 3: middle estimate off by 2.9-fold (0.46 log units), on the low side; low and high end bracket the measured number.
By their numbers in this assay, from the lowest: compound 1; then compounds 2 and 3 (each within the scatter of the next).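

In this assay, 3,5-dimethoxyphenyl in place of ((furan-2-yl)methyl)sulfanyl gives a 1.8-fold higher number from compound 2 to compound 3 (0.26 log units; within the scatter), so the two groups cannot be ordered on this read-out. This carbon, ortho to a large group and meta to a trifluoromethyl group, therefore accepts a six-membered aromatic ring of carbon only as well as a sulfanyl-linked five-membered aromatic ring with 1 hetero atom, and the exchange produces no separable difference between these two compounds. Compound 1 now stands apart from two different replacements rather than one: the large step, a 15-fold higher number from compound 1 to compound 3 (1.16 log units; beyond the scatter), joins an 8.0-fold higher number from compound 1 to compound 2 (0.90 log units; beyond the scatter), and among these three compounds only the 4-(trifluoromethyl)piperidin-1-yl group gives a number beyond the scatter of the others.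

The compounds shown leave open whether the low number of compound 1 goes with the ring amine on the aromatic carbon or with the trifluoromethyl group on that ring, a question that an unsubstituted piperidin-1-yl or an open-chain dimethylamino group at this carbon would bear on directly. Nothing at hand accounts for the differences among these three compounds.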